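The compounds below may be only part of what the source reports. "The series", "measured", "known", "first", "only" and "open" are said of these compounds alone.

Measured so far in an assay on isolated protein for displacement of a labelled ligand from melanin-concentrating hormone receptor 1 (Homo sapiens); a higher number here means a weaker inhibitor, a lower number a stronger inhibitor:
compound 1 `O=C(CCc1ccc(C(F)(F)F)cc1)Nc1ccc2nc(N3CCC3)ccc2c1` gives 4 nM;
compound 2 `O=C(CCc1ccc(C(F)(F)F)cc1)Nc1ccc2nc(N3CC4CC3CN4)ccc2c1` gives 210 nM;
compound 3 `CC1CCN(c2ccc3cc(NC(=O)CCc4ccc(C(F)(F)F)cc4)ccc3n2)C1` gives 2 nM.

Compound 3 carries the lowest number of the three, but compound 1 lies within the scatter of it (a 2.0-fold lower number from compound 1 to compound 3 (0.30 log units; within the scatter)), while compound 2 stands far above (a 110-fold lower number from compound 2 to compound 3 (2.02 log units; beyond the scatter)). Compound 4 `O=C(CCc1ccc(C(F)(F)F)cc1)Nc1ccc2nc(N3CC4CC3CO4)ccc2c1` is the next step: a group of 7 heavy atoms (5 carbon, 1 nitrogen, 1 oxygen; 2 five-membered non-aromatic rings with 1 hetero atom each) in place of a group of 6 heavy atoms (5 carbon, 1 nitrogen; one five-membered non-aromatic ring with 1 hetero atom), on an aromatic carbon. The entering group is a bridged pair of rings of the same shape as in compound 2, with oxygen where compound 2 has its second nitrogen. For the measured compounds named here, the steps that bear on this are a 53-fold higher number from compound 1 to compound 2 (1.72 log units; beyond the scatter) and a 110-fold lower number from compound 2 to compound 3 (2.02 log units; beyond the scatter), both large and both against the bridged group. Going by the values given here, a clear rise in this assay is therefore expected for compound 4, with wide uncertainty since no oxygen-bridged analogue has been measured. The estimate for compound 4 is 100 nM, between 20 nM and 500 nM, meaning an expected step of a 50-fold higher number from compound 3 to compound 4 (1.70 log units; beyond the scatter).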

Compound 4, half-maximal inhibitory concentration: 13 nM
Estimate against measurement, compound 4: 7.7-fold (0.89 log units) above; measured number outside the range, below it.
By their numbers in this assay, from the lowest: compounds 3 and 1 (each within the scatter of the next); then compound 4; then compound 2.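

In this assay, the large penalty seen with the bridged group in compound 2 depends on the atom at the bridge and not on the bridged shape alone: oxygen in place of the second nitrogen recovers most of the loss (a 16-fold lower number from compound 2 to compound 4 (1.21 log units; beyond the scatter)). A modest cost remains against both 3-methylpyrrolidin-1-yl (a 6.5-fold higher number from compound 3 to compound 4 (0.81 log units; beyond the scatter)) and azetidin-1-yl (a 3.3-fold higher number from compound 1 to compound 4 (0.51 log units; beyond the scatter)). No evidence on hand explains the difference between the oxygen and nitrogen bridges. Still open, as far as these compounds go, is how a bridged group with carbon at that atom would compare, and whether a methyl or acetyl group on the second nitrogen would restore the number.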